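Swapping the Phenyl of Compound 3 for a Dihydroxypropyl Chain

The source may report more compounds than this note shows. Statements on the series, on what has been measured and on what is new or still open speak of the compounds shown alone.

Three measured compounds share one core and differ only in a single group. In a functional assay on the whole organism (strain Albino Wistar) for inhibition, with Rattus norvegicus as the target, read by paw edema, with stated times of 1 h and 5 h, at a dose of 10 mg/kg by the oral route (on this read-out lower numbers stand for less inhibition and higher numbers for more inhibition at the one dose given (going by the name of the read-out)), compound 1 `Clc1ccc(-n2cc(CSc3nc4ccccc4s3)nn2)cc1` gives 43.4%. Compound 2 `Fc1ccc(-n2cc(CSc3nc4ccccc4s3)nn2)cc1` gives 81.1%. Compound 3 `c1ccc(-n2cc(CSc3nc4ccccc4s3)nn2)cc1` gives 32.1%, the lowest of the three: the step of a number 11.3 percentage points lower from compound 1 to compound 3 (beyond the scatter) and the step of a number 49 percentage points lower from compound 2 to compound 3 (beyond the scatter) both lead down to it. Compound 4 `OCC(O)Cn1cc(CSc2nc3ccccc3s2)nn1` changes a different place: 2,3-dihydroxypropyl in place of phenyl on an aromatic nitrogen. Among the measured compounds shown here, every measured step, including a number 37.7 percentage points higher from compound 1 to compound 2 (beyond the scatter), concerns only the halogen on the phenyl, so no measured step bears on this change, and the expectation is a step of no clear direction, with wide uncertainty. Compound 4 is estimated at 35%, between 12% and 62%, an expected step of a number 2.9 percentage points higher from compound 3 to compound 4 (within the scatter).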

Compound 4, a percentage reported as inhibition, in the whole organism at one dose (the size of the read-out at that dose, not a potency): 52.8%
The estimate for compound 4 lay 17.8 percentage points below the measured number; low and high end bracket the measured number.
By their numbers in this assay, from the lowest: compound 3; then compounds 1 and 4 (each within the scatter of the next); then compound 2.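

At this aromatic nitrogen, an aromatic ring is not needed for activity: the ringless 2,3-dihydroxypropyl chain gives a number 20.7 percentage points higher from compound 3 to compound 4 (beyond the scatter). The same chain still falls short of 4-fluorophenyl, with a number 28.3 percentage points lower from compound 2 to compound 4 (beyond the scatter), while against 4-chlorophenyl it gives a number 9.4 percentage points higher from compound 1 to compound 4 (within the scatter). Nothing shown explains how the chain produces these differences.

Still open, going by these compounds, is whether the two hydroxyl groups matter or the chain alone is enough, which a plain propyl chain would test. Also open, on these data alone, is how an amine, a carboxylic acid or a longer chain would fare at this nitrogen.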